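A few compounds are considered here, and "the series" means these few. Any claim that something is new, unique, unknown or untested is made for them only; others in the source may bear on it.

The four compounds share a core that carries, on a sulfur attached to a saturated chain carbon, a five-membered heteroaromatic ring. Compound 1 `Cc1nnc(SCc2cc(=O)c3cc(Cl)ccc3o2)o1` was tested in a functional assay on SW480 cells (Homo sapiens) for cytotoxicity, read by MTT assay, with a stated time of 72 h; on this read-out lower numbers stand for stronger inhibition and higher numbers for weaker inhibition. In this assay compound 1 gives only a limit, > 25000 nM. Compound 2 `Nc1nnc(SCc2cc(=O)c3cc(Cl)ccc3o2)s1` likewise gives only a limit in this assay, > 25000 nM. Compound 2 differs from compound 1 by 5-amino-1,3,4-thiadiazol-2-yl in place of 5-methyl-1,3,4-oxadiazol-2-yl on a sulfur, and the step that the two limits leave unreadable from compound 1 to compound 2 cannot be read because of the limit of > 25000 nM in this assay, at which 2 of the 3 values shown sit. Compound 3 `Cc1nnc(SCc2coc3ccccc3c2=O)o1` has a different core; how the core of compound 3 differs from the core of compound 1 is not broken down here. In this assay, within the data shown here, compound 3 gives 790 nM, the only number among the three measured compounds. Compound 4 `Nc1nnc(SCc2coc3ccccc3c2=O)s1` has not been measured. It differs from compound 3 by 5-amino-1,3,4-thiadiazol-2-yl in place of 5-methyl-1,3,4-oxadiazol-2-yl on a sulfur, the same change that turns compound 1 into compound 2, at the same place. Since that earlier step is unreadable, no size can be carried over, so the step from compound 3 is expected to be small, a 1.9-fold higher number from compound 3 to compound 4 (0.28 log units; within the scatter), resting only on the value of compound 3. Compound 4 is therefore expected to give about 1500 nM in this assay, between 300 nM and 12000 nM.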

Compound 4, half-maximal inhibitory concentration: > 25000 nM
Compound 4: a limit, no number (the forecaster's own chance of this, stated with the estimate: 25%); middle value at least 16-fold (1.22 log units) from the limit.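

In this assay, the change to 5-amino-1,3,4-thiadiazol-2-yl in place of 5-methyl-1,3,4-oxadiazol-2-yl on a sulfur gives an at least 31-fold higher number from compound 3 to compound 4 (1.50 log units; beyond the scatter), so on the core of compound 3 this change carries a large loss of inhibition. Compound 4 gives > 25000 nM, which is a limit of the assay and not a number. The same change on the core of compound 1 cannot be read, so the series does not show whether the change has a similar size on both cores, and this single readable pair sets no rule for carrying it from one core to another: the limit of > 25000 nM in this assay, at which 3 of the 4 values shown sit.

The compounds shown leave open whether the step follows the change of ring or the change from methyl to amino, which a 5-methyl-1,3,4-thiadiazol-2-yl group on the same sulfur would help to separate. They also leave open how an ethyl group or a carboxylic acid in that place on the ring would read on the core of compound 3.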